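From trifluoromethyl to isopropoxy: a working estimate

This account rests on a few compounds, and the source may have more. Where it says the series, first, only, none or still open, it means among the compounds named here.

In an ADME assay on L6 cells (Rattus norvegicus) for cytotoxicity, read by resazurin assay, with a stated time of 72 h (on this read-out higher numbers stand for weaker inhibition and lower numbers for stronger inhibition), compound 1 `CC(C)Oc1ccc(C(O)(c2ccc(Cl)cc2)c2cccnc2)cc1` gives 56600 nM and compound 2 `CC(C)Oc1ccc(C(O)(c2ccc(C(F)(F)F)cc2)c2cccnc2)cc1` gives 47600 nM on the same read-out. The step is a 1.2-fold lower number from compound 1 to compound 2 (0.08 log units; within the scatter) and so compound 2 stands level with compound 1, with no separation between them.

Compound 3 `CC(C)Oc1ccc(C(O)(c2ccc(OC(C)C)cc2)c2cccnc2)cc1` carries isopropoxy in place of trifluoromethyl on an aromatic carbon, para to a large group: isopropoxy in place of trifluoromethyl on an aromatic carbon is the whole change. Within the data shown here, one measured step bears on that place, namely a 1.2-fold lower number from compound 1 to compound 2 (0.08 log units; within the scatter) with trifluoromethyl replacing chloro. That single step is thin evidence, yet it gives no ground for expecting a step beyond the scatter in this assay here. The estimated change is a 1.1-fold lower number from compound 2 to compound 3 (0.02 log units; within the scatter) and is expected to stay within the scatter. Compound 3 is expected at 45000 nM with an estimated range from 20000 nM to 90000 nM on this read-out.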

Compound 3, half-maximal inhibitory concentration: 61400 nM
Compound 3: the middle estimate sits 1.4-fold (0.13 log units) below what was measured; measured number inside the range.
By their numbers in this assay, from the lowest: compounds 2, 1 and 3 (each within the scatter of the next).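

In this assay isopropoxy in place of trifluoromethyl gives a 1.3-fold higher number from compound 2 to compound 3 (0.11 log units; within the scatter) at this position, and isopropoxy in place of chloro gives a 1.1-fold higher number from compound 1 to compound 3 (0.04 log units; within the scatter) on the same read-out. The earlier pair compared only chloro and trifluoromethyl, whereas compound 3 extends the comparison to isopropoxy, a group with oxygen as its link to the aromatic carbon, and compound 1, compound 2 and compound 3 still stand level. No supporting data are available to account for this flat result.

Still open, as far as these compounds go, is whether an amine, a carboxylic acid or a longer chain at this position would separate from these three compounds in this assay at all. All three share the rest of the core, so the result speaks for this one position only and not for changes elsewhere on the series.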